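Moving the fluorine on the aryl ring of compound 3

A few compounds are considered here, and "the series" means these few. Any claim that something is new, unique, unknown or untested is made for them only; others in the source may bear on it.

Of the compounds shown here, three sharing one core have been tested in a functional assay on HeLa cells (Homo sapiens) for cytotoxicity, read by MTT assay, with a stated time of 48 h, tested at 50 uM; on this read-out higher numbers stand for a stronger effect at the one concentration tested and lower numbers for a weaker effect. Compound 1 `CS(=O)(=O)c1ccc(Cc2n[nH]c(=S)n2/N=C/c2cccnc2)cc1` gives 14%. Compound 2 `CS(=O)(=O)c1ccc(Cc2n[nH]c(=S)n2/N=C/c2ccccc2Cl)cc1` gives 42.7%. Compound 3 `CS(=O)(=O)c1ccc(Cc2n[nH]c(=S)n2/N=C/c2ccc(F)cc2)cc1` gives 26.3%. Among these three numbers compound 3 stands second highest: a number 12.3 percentage points higher from compound 1 to compound 3 (beyond the scatter), whereas a number 16.4 percentage points lower from compound 2 to compound 3 (beyond the scatter).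

Compound 4 `CS(=O)(=O)c1ccc(Cc2n[nH]c(=S)n2/N=C/c2ccccc2F)cc1` has not yet been measured. It differs from compound 3 in one place only, the two having the same atoms joined differently: 2-fluorophenyl in place of 4-fluorophenyl on a carbon with a double bond to nitrogen.

Among the measured compounds shown here, no measured step makes exactly this change. The nearest guide is the step from a halogen-bearing phenyl of one kind to another, a number 16.4 percentage points lower from compound 2 to compound 3 (beyond the scatter), and the step of a number 28.7 percentage points higher from compound 1 to compound 2 (beyond the scatter) shows the same 2-chlorophenyl compound highest. Both steps were modest in size. A modest rise in this assay is therefore expected for compound 4, as a number 8.7 percentage points higher from compound 3 to compound 4 (within the scatter). Compound 4 is estimated at 35%, most likely between 20% and 50%.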

Compound 4, a percentage reported as activity, at one concentration (the size of the read-out at that concentration, not a potency): 21.9%
Compound 4: the middle estimate sits 13.1 percentage points above what was measured, within the range that was stated.
By their numbers in this assay, from the lowest: compounds 1, 4 and 3 (each within the scatter of the next, the first and the last beyond it); then compound 2.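

In this assay, moving the fluorine from 4-fluorophenyl to 2-fluorophenyl gives a number 4.4 percentage points lower from compound 3 to compound 4 (within the scatter), and 2-fluorophenyl in place of pyridin-3-yl gives a number 7.9 percentage points higher from compound 1 to compound 4 (within the scatter), so compound 4 cannot be told apart from either neighbour. The halogen itself matters more here: fluoro in place of chloro on an aromatic carbon gives a number 20.8 percentage points lower from compound 2 to compound 4 (beyond the scatter), so the high number of the 2-chlorophenyl compound does not carry over to its 2-fluorophenyl counterpart. No independent measurement is available to explain these differences.

The compounds shown leave open how an atom or group such as a bromine, a methoxy group or an amine would behave in place of that fluorine. They also leave open whether these differences would hold at other concentrations, since each number comes from a single one.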